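Chlorine to Fluorine on the Benzyl Arm: Cytotoxicity Outlook

The source may hold more compounds than are shown below. What is called first, only, known or untested is meant among the compounds shown, and "the series" means these compounds.

Three compounds of one shared core were examined in an ADME assay on NIH3T3 cells (Mus musculus) for cytotoxicity, with a stated time of 72 h; on this read-out lower numbers stand for stronger inhibition and higher numbers for weaker inhibition. Among the measured compounds shown here, compound 1 `Cc1ccc(CNc2ncnc3c2ncn3[C@@H]2O[C@H](CO)[C@@H](O)[C@H]2O)cc1` is the only member with a reported result. In this assay compound 1 gives > 166000 nM, which is a limit of the assay rather than a number. Compound 2 `OC[C@H]1O[C@@H](n2cnc3c(NCc4ccc(Cl)cc4Cl)ncnc32)[C@H](O)[C@@H]1O` was also entered in this assay, where compound 2 is recorded as "not determined" (no result reported), so no number stands for it. Compound 2 therefore has no place on the numbers shown, and the whole series is described by a single entry, namely (the limit of > 166000 nM in this assay, at which 1 of the 2 values shown sits). Compound 3 `OC[C@H]1O[C@@H](n2cnc3c(NCc4ccc(F)cc4F)ncnc32)[C@H](O)[C@@H]1O` differs from compound 2 in one place: 2,4-difluorophenyl in place of 2,4-dichlorophenyl on a saturated chain carbon bound to a nitrogen on an aromatic ring. For the measured compounds named here, since no step between measured compounds exists, no size can be read for the move from compound 2 to compound 3 in this assay; the expectation is a change of no more than the scatter, with compound 3 most likely sitting near the limit as compound 1 does. Compound 3 is expected to give about 166000 nM in this assay, within a range from 70000 nM to 350000 nM, with a substantial chance that only a limit is reported.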

Compound 3, half-maximal inhibitory concentration: > 166000 nM
Compound 3: a limit, no number (the forecaster's own chance of this, stated with the estimate: 75%); the middle value lies on the limit itself.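

Compound 1 and compound 3 both sit at a limit of the assay and compound 2 has no reported result, so no new step can be read among these compounds: the limit of > 166000 nM in this assay, at which 2 of the 3 values shown sit.

The compounds shown leave open whether 2,4-dichlorobenzyl and 2,4-difluorobenzyl on the shared core differ at all in this assay.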